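The compounds below may be only part of what the source reports. "The series", "measured", "known", "first", "only" and "open" are said of these compounds alone.

Working notes on the series.

Three members of the series have been measured, all built on one shared core. Compound 1 `OC[C@H]1OC(n2c(SCc3ccc(Br)cc3)nc3cc(Cl)c(Cl)cc32)[C@H](O)[C@@H]1O` gives 20000 nM in a functional assay on KB cells (Homo sapiens) for inhibition; a lower number here means a stronger inhibitor, a higher number a weaker inhibitor. Compound 2 `OC[C@H]1OC(n2c(SCc3cccc(Cl)c3)nc3cc(Cl)c(Cl)cc32)[C@H](O)[C@@H]1O` gives 19000 nM in this assay. Compound 3 `O=[N+]([O-])c1ccc(CSc2nc3cc(Cl)c(Cl)cc3n2C2O[C@H](CO)[C@@H](O)[C@H]2O)cc1` gives 30000 nM in this assay. Compound 3 holds the highest of the three numbers, but its distance to the other two is small: a 1.5-fold higher number from compound 1 to compound 3 (0.18 log units; within the scatter), and a 1.6-fold higher number from compound 2 to compound 3 (0.20 log units; within the scatter). The remaining pair behaves the same way, with a 1.1-fold lower number from compound 1 to compound 2 (0.02 log units; within the scatter).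

Compound 4 `OC[C@H]1OC(n2c(SCc3cccc(C(F)(F)F)c3)nc3cc(Cl)c(Cl)cc32)[C@H](O)[C@@H]1O` is not yet measured. Against compound 3 the change is 3-(trifluoromethyl)phenyl in place of 4-nitrophenyl on a saturated chain carbon bound to a sulfur.

Among the compounds with values here, two measured steps bear directly on this place. The step of a 1.6-fold higher number from compound 2 to compound 3 (0.20 log units; within the scatter) exchanged the group on the saturated chain carbon bound to a sulfur, and the step of a 1.5-fold higher number from compound 1 to compound 3 (0.18 log units; within the scatter) exchanged the substituent on the aromatic ring of that group. Neither left the scatter, and a 1.1-fold lower number from compound 1 to compound 2 (0.02 log units; within the scatter) did not either. Every exchange made so far at this position has moved the number by less than the scatter, so for compound 4 no step beyond the scatter is expected in this assay in either direction.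

Compound 4 is therefore expected to give about 20000 nM in this assay, with a range from 9000 nM to 45000 nM. The step so expected is a 1.5-fold lower number from compound 3 to compound 4 (0.18 log units; within the scatter).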

Compound 4, half-maximal inhibitory concentration: 15000 nM
Compound 4: middle estimate off by 1.3-fold (0.12 log units), on the high side, within the range that was stated.
By their numbers in this assay, from the lowest: compounds 4, 2, 1 and 3 (each within the scatter of the next).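

Within the data shown here, with 3-(trifluoromethyl)phenyl, a fourth group now stands on the saturated chain carbon bound to a sulfur, and in this assay each of its steps to the earlier compounds stays within the scatter (a 2.0-fold lower number from compound 3 to compound 4 (0.30 log units; within the scatter); a 1.3-fold lower number from compound 2 to compound 4 (0.10 log units; within the scatter); a 1.3-fold lower number from compound 1 to compound 4 (0.12 log units; within the scatter)). The exchange against compound 3 is also the first at this place to replace 4-nitrophenyl, with 2 hydrogen-bond acceptors, by a group with 0 hydrogen-bond acceptors, and the number still does not leave the scatter; the same holds for trifluoromethyl in place of chloro on an aromatic carbon, going from compound 2 to compound 4. No measurement is available that would explain these numbers.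

On these data alone, all four groups at this place are substituted phenyl rings, so it remains open whether an amine, a carboxylic acid or a longer chain there would move the number in this assay beyond the scatter. As far as these compounds go, the shared core is the same in all four compounds, so the effect of any change elsewhere in the structure also remains open.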